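The compounds below may be only part of what the source reports. "The series", "measured", "known", "first", "only" and "open" are said of these compounds alone.

Among the compounds with values here, compound 2 `O=C(CSc1nnc(-c2ccncc2)n1-c1ccccc1)N/N=C/c1ccc(Br)cc1` stands lowest of the two numbers so far in a functional assay on HCT-116 cells (Homo sapiens) for inhibition, read by MTT assay, with a stated time of 48 h (on this read-out higher numbers stand for weaker inhibition and lower numbers for stronger inhibition), at 4500 nM. Compound 1 `O=C(CSc1nnc(-c2ccncc2)n1-c1ccccc1)N/N=C/c1ccccc1` gives 14700 nM in this assay, and the step of a 3.3-fold lower number from compound 1 to compound 2 (0.51 log units; beyond the scatter) is the only one measured. Compound 3 `O=C(CSc1nnc(-c2ccncc2)n1-c1ccccc1)N/N=C/c1cccc(F)c1` differs from compound 2 by 3-fluorophenyl in place of 4-bromophenyl on a carbon with a double bond to nitrogen. Within the data shown here, no measured step covers a fluorine entering; only the bromine-for-hydrogen step bears on it, and it was modest. The step of a 2.0-fold higher number from compound 2 to compound 3 (0.30 log units; within the scatter) is expected to be a rise, since the bromine carried by the step of a 3.3-fold lower number from compound 1 to compound 2 (0.51 log units; beyond the scatter) is lost. Compound 3 is estimated at 9000 nM, range 3000 nM to 27000 nM.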

Compound 3, half-maximal inhibitory concentration: > 50000 nM
Compound 3 gave a limit, no number; the forecaster's own chance of this, stated with the estimate: 5%; at least 5.5-fold (0.74 log units) between middle value and limit.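

For compound 3 the result in this assay is a limit of the assay and not a number: the limit of > 50000 nM in this assay, at which 1 of the 3 values shown sits. Placing 3-fluorophenyl in place of 4-bromophenyl on this carbon with a double bond to nitrogen gives an at least 11-fold higher number from compound 2 to compound 3 (1.04 log units; beyond the scatter), so this aryl group can move the read-out strongly upward as well as downward. Fluoro in place of hydrogen gives an at least 3.4-fold higher number from compound 1 to compound 3 (0.53 log units; beyond the scatter), so a halogen on this ring does not in itself lower the number, with compound 2 going the other way.

Still open, on these data alone, is whether the halogen or its place on the ring drives the loss, as 4-bromophenyl and 3-fluorophenyl differ in both. As far as these compounds go, how a methoxy group or an amine on this ring would read is also open.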